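Extending the Ester Chain from Compound 2 to Compound 3

The source may report more compounds than this note shows. Statements on the series, on what has been measured and on what is new or still open speak of the compounds shown alone.

Among the compounds with values here, in an ADME assay on CCRF-CEM cells (Homo sapiens) for inhibition (a higher number here means that more compound is tolerated, a lower number that less compound is tolerated), compound 1 (`CCCCOC(=O)c1cc(O)c(O)c(O)c1`) gives 55000 nM, and compound 2 (`CCCCCCOC(=O)c1cc(O)c(O)c(O)c1`) gives 14000 nM, the lower of the two numbers so far. Compound 3 (`CCCCCCCCOC(=O)c1cc(O)c(O)c(O)c1`) departs from compound 2 by ethyl in place of hydrogen on a saturated chain carbon, six bonds along the chain from an oxygen next to a carbonyl group. Within the data shown here, one measured step bears on this change, the same replacement made four bonds along the chain: a 3.9-fold lower number from compound 1 to compound 2 (0.59 log units; beyond the scatter). Among the measured compounds shown here, that modest step is the only guide, and a single step establishes no trend. A step of similar size in the same direction is therefore expected, though the data cannot show whether it will persist further along the chain. The expected step is a 2.8-fold lower number from compound 2 to compound 3 (0.45 log units; beyond the scatter). For compound 3, the estimated value in this assay is 5000 nM, within an expected range of 2000 nM to 14000 nM.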

Compound 3, half-maximal cytotoxic concentration: 11000 nM
The estimate for compound 3 lay 2.2-fold (0.34 log units) below the measured number; the measured number falls inside the stated range.
By their numbers in this assay, from the lowest: compounds 3 and 2 (each within the scatter of the next); then compound 1.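

In this assay, the ethyl replacement made six bonds along the chain gives a 1.3-fold lower number from compound 2 to compound 3 (0.10 log units; within the scatter), so this change does not separate compound 3 from compound 2, although the same replacement made four bonds along the chain moved the number beyond the scatter. Butyl in place of hydrogen, four bonds along the chain, gives a 5.0-fold lower number from compound 1 to compound 3 (0.70 log units; beyond the scatter), which shows that compound 3 stands clearly apart from compound 1, much as compound 2 already did. No experimental evidence here explains why the second extension leaves the number within the scatter.

Three straight-chain esters cannot show whether a longer chain would leave the number level or move it again. As far as these compounds go, the effect of a branched chain, or of an amine or a carboxylic acid at the chain end, also remains open.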